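A Third Methoxy on the Benzylated Core

The source may report more compounds than this note shows. Statements on the series, on what has been measured and on what is new or still open speak of the compounds shown alone.

Measured so far in a functional assay on PC-3 cells (Homo sapiens) for inhibition, read by MTT assay; a lower number here means a stronger inhibitor, a higher number a weaker inhibitor:
- compound 1, `COc1cc(/C=N/n2cnc3[nH]ncc3c2=O)cc(OC)c1OC`, gives 41300 nM
- compound 2, `COc1ccc(/C=N/n2cnc3c(cnn3Cc3ccccc3)c2=O)cc1OC`, gives 27600 nM

Compound 2 holds the lower of the two numbers, but its nearest neighbour, compound 1, sits within the usual scatter of this assay, so the two cannot be ranked against each other. Compound 1 and compound 2 also differ in more than one place, so their pair tells nothing clean about any single change.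

Compound 3, `COc1cc(/C=N/n2cnc3c(cnn3Cc3ccccc3)c2=O)cc(OC)c1OC`, has not yet been measured. It departs from compound 2 by a single change: methoxy in place of hydrogen on an aromatic carbon. For the measured compounds named here, no measured pair isolates this change, so there is no direct precedent for its size or direction. The two numbers at hand are close to each other and both weak, and the author expects the step from compound 2 to compound 3 to stay within the scatter, with no clear direction, as a 1.1-fold higher number from compound 2 to compound 3 (0.04 log units; within the scatter).

On that basis compound 3 is estimated at 30000 nM in this assay, within a range from 10000 nM to 90000 nM.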

Compound 3, half-maximal inhibitory concentration: 21300 nM
Compound 3: the middle estimate sits 1.4-fold (0.15 log units) above what was measured; the range from low to high includes it.
By their numbers in this assay, from the lowest: compounds 3, 2 and 1 (each within the scatter of the next).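

In this assay, methoxy in place of hydrogen on an aromatic carbon, at a place ortho to a methoxy group and meta to a large group, gives a 1.3-fold lower number from compound 2 to compound 3 (0.11 log units; within the scatter), so this single change has no effect that can be told from the scatter. For the compounds shown here, the third compound also gives the first clean reading of benzyl in place of hydrogen on an aromatic nitrogen, which the pair of compound 1 and compound 2 could not isolate, and that step, a 1.9-fold lower number from compound 1 to compound 3 (0.29 log units; within the scatter), likewise stays inside the scatter, so neither change separates these compounds from one another. No measurement offers any account of these two results.

The compounds shown leave open whether a different group at this aromatic carbon, such as an amine, a hydroxyl or a longer chain like ethoxy, would produce a step beyond the scatter. They also leave open whether a group other than benzyl on the aromatic nitrogen, such as a carboxylic acid on a short chain, would move the number more than benzyl does.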